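The source may hold more compounds than are shown below. What is called first, only, known or untested is meant among the compounds shown, and "the series" means these compounds.

Series notes on cytotoxicity, read in an ADME assay on Huh-7 cells (Homo sapiens) for cytotoxicity, with a stated time of 72 h; on this read-out lower numbers stand for higher toxicity in this test and higher numbers for lower toxicity in this test. Three compounds carry a measurement, and each is only a limit of the test. For compound 1 `CS(=O)(=O)Nc1ccc2c(c1)S(=O)(=O)N=C(C1=C(O)C3CCCC3N(Cc3ccc(F)cn3)C1=O)N2` the read-out is a limit, > 33000 nM. For compound 2 `CS(=O)(=O)Nc1ccc2c(c1)S(=O)(=O)N=C(C1=C(O)[C@H]3CCC[C@H]3N(Cc3ccc(F)c(F)c3)C1=O)N2` the read-out is likewise a limit, > 1000 nM. Compound 3 `CC(C)(C)CCN1C(=O)C(C2=NS(=O)(=O)c3cc(NS(C)(=O)=O)ccc3N2)=C(O)C2CCCCC21` also sits at a limit, > 33000 nM. For the measured compounds named here, compound 3 thus stands at the limit of > 33000 nM in this assay, at which 2 of the 3 values shown sit, rather than at the limit of > 1000 nM in this assay, at which 1 of the 3 values shown sits; no numbered value separates it from the others, and no step between measured compounds can be sized.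

Compound 4 `CS(=O)(=O)Nc1ccc2c(c1)S(=O)(=O)N=C(C1=C(O)C3CCCCC3N(Cc3ccc(F)cc3)C1=O)N2` remains to be measured in this assay. It differs from compound 3 by 4-fluorophenyl in place of neopentyl on a saturated chain carbon bound to an amide-type nitrogen in a ring. Going by the values given here, compound 1 and compound 2 likewise show no resolved toxicity in the set, so nothing so far points to a measurable effect at this position. The step from compound 3 to compound 4 is therefore expected to be none beyond the scatter, a step that the limit leaves unreadable from compound 3 to compound 4, with a high chance that again only a limit is reported. Compound 4 is estimated at 40000 nM, within 15000 nM to 120000 nM.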

Compound 4, half-maximal cytotoxic concentration: > 33000 nM
Compound 4 was reported as a limit; the forecaster's own chance of this, stated with the estimate: 85%; the middle value does not contradict the limit.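

For the compounds shown here, compound 3 and compound 4 both stand only as limits in this assay, and no step between them can be read. The compounds shown leave open whether 4-fluorophenyl in place of neopentyl alters the half-maximal cytotoxic concentration, and at what concentration any of these compounds becomes toxic to these cells.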